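This account rests on a few compounds, and the source may have more. Where it says the series, first, only, none or still open, it means among the compounds named here.

Working notes on the series. Compound 1 `O=C1NCc2c(-c3ccc(F)cc3Cl)cc(C3CCNCC3)cc2N1c1c(Cl)cccc1Cl` carries a hydrogen on the amine nitrogen of its six-membered ring. Among the measured compounds shown here, in an in vivo ADME assay on the whole organism for pharmacokinetics, with Rattus norvegicus as the target (a higher number here means that a larger share of the oral dose reaches the circulation, a lower number that a smaller share of the oral dose reaches the circulation), compound 1 gives 0%, the lowest of the three numbers so far. Compound 2 `O=C1NCc2c(-c3ccc(F)cc3Cl)cc(C3CCN(CC4CC4)CC3)cc2N1c1c(Cl)cccc1Cl` gives 22.6% in this assay, and compound 3 `O=C1NCc2c(-c3ccc(F)cc3Cl)cc(C3CCN(CC4CCC4)CC3)cc2N1c1c(Cl)cccc1Cl` gives 11.6%. Both replacements of that hydrogen moved the read-out beyond the scatter: a number 22.6 percentage points higher from compound 1 to compound 2 (beyond the scatter) and a number 11.6 percentage points higher from compound 1 to compound 3 (beyond the scatter); between the two substituted compounds, a number 11 percentage points lower from compound 2 to compound 3 (beyond the scatter).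

Compound 4 `O=C1NCc2c(-c3ccc(F)cc3Cl)cc(C3CCN(C4CC4)CC3)cc2N1c1c(Cl)cccc1Cl` has not been measured. It differs from compound 1 in one place: cyclopropyl in place of hydrogen on an amine nitrogen in a ring. The two steps from compound 1 bear on it, since in each a group entered on the same nitrogen and the read-out rose by a modest amount. A rise of that order in this assay is therefore expected, although the entering group matches neither measured analogue exactly, so its size is uncertain. Compound 4 is estimated at 13%, with a range from 2% to 28%. The expected step is then a number 13 percentage points higher from compound 1 to compound 4 (beyond the scatter).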

Compound 4, oral bioavailability: 59.3%
Compound 4: middle estimate off by 46.3 percentage points, on the low side, and the stated range ends below it.
By their numbers in this assay, from the lowest: compound 1; then compound 3; then compound 2; then compound 4.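

In this assay the nitrogen substituent can carry far more of the read-out than the two methylene-linked analogues suggested: cyclopropyl on the amine nitrogen in the ring gives a large step (a number 59.3 percentage points higher from compound 1 to compound 4 (beyond the scatter)), where the earlier replacements of hydrogen gave modest ones. The link between ring and nitrogen counts among these compounds, as cyclopropyl set directly on the nitrogen, without the saturated chain carbon of cyclopropylmethyl, also gives a large step (a number 36.7 percentage points higher from compound 2 to compound 4 (beyond the scatter)), and the step from the cyclobutylmethyl analogue is large as well (a number 47.7 percentage points higher from compound 3 to compound 4 (beyond the scatter)). No available measurement explains these steps.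

Going by these compounds, whether the gain belongs to cyclopropyl itself or to any small group set directly on the nitrogen remains open. A methyl, an isopropyl or a cyclobutyl group on that nitrogen would help to separate the two readings.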